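The source may report more compounds than this note shows. Statements on the series, on what has been measured and on what is new or still open speak of the compounds shown alone.

Of the compounds shown here, three sharing one core have been tested in a functional assay on SR cells (Homo sapiens) for inhibition, read by sulforhodamine B assay, with a stated time of 48 h, tested at 0.1 uM; a lower number here means a stronger effect, a higher number a weaker effect of the compound at the concentration tested. Compound 1 `COc1cc(Cl)cc(-c2nn(-c3cccc(NC(=O)Nc4ccc(Cl)c(C(F)(F)F)c4)c3)cc2-c2ccncc2)c1` gives 92% in this assay, and compound 2 `COc1cc(Cl)cc(-c2nn(-c3cccc(NC(=O)Nc4cc(C(F)(F)F)cc(C(F)(F)F)c4)c3)cc2-c2ccncc2)c1` gives 92%. Compound 3 `COc1cc(Cl)cc(-c2nn(-c3cccc(NC(=O)Nc4ccc(Cl)c(Cl)c4)c3)cc2-c2ccncc2)c1` gives 51%, the lowest of the three numbers; its nearest neighbour, compound 1, and its furthest, compound 2, both stand higher by a gap beyond the scatter. Among the compounds with values here, the only single-point step among the measured compounds, chloro in place of trifluoromethyl on an aromatic carbon, reads a number 41 percentage points lower from compound 1 to compound 3 (beyond the scatter), a large drop.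

Compound 4 `COc1cc(Cl)cc(-c2nn(-c3cccc(NC(=O)Nc4cccc(C(F)(F)F)c4)c3)cc2-c2ccncc2)c1` has not yet been measured. It differs from compound 3 in one place: 3-(trifluoromethyl)phenyl in place of 3,4-dichlorophenyl on an amide-type nitrogen. Within the data shown here, this change brings back a ring carrying trifluoromethyl, as in compound 1 with 92% and compound 2 with 92%, so the one relevant step points toward a rise in this assay. Among the measured compounds shown here, the step of a number 34 percentage points higher from compound 3 to compound 4 (beyond the scatter) is therefore expected, a rise of about the size seen before, though compound 4 keeps no chloro on that ring and the data hold no compound of exactly this kind. The estimate for compound 4 in this assay is 85%, within a range from 60% to 100%.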

Compound 4, a percentage reported as activity, at one concentration (the size of the read-out at that concentration, not a potency): 93%
The estimate for compound 4 lay 8 percentage points below the measured number; the range from low to high includes it.
By their numbers in this assay, from the lowest: compound 3; then compounds 1, 2 and 4 (each within the scatter of the next).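

In this assay, the step of a number 42 percentage points higher from compound 3 to compound 4 (beyond the scatter) shows that, on the amide-type nitrogen, 3-(trifluoromethyl)phenyl alone is enough to give a read-out far from that of 3,4-dichlorophenyl. The extra groups on that ring make no difference once trifluoromethyl is present: taking away the chloro of compound 1 gives a number 1 percentage points higher from compound 1 to compound 4 (within the scatter), and taking away the second trifluoromethyl of compound 2 gives a number 1 percentage points higher from compound 2 to compound 4 (within the scatter). Among these four compounds, the three with trifluoromethyl on this ring therefore read alike, and only compound 3, which has none, stands apart.

No measurement here accounts for this difference. As far as these compounds go, it remains open how a ring with a single chloro, or one with a methoxy, a nitrile or an amine in place of trifluoromethyl, would read.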